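This account rests on a few compounds, and the source may have more. Where it says the series, first, only, none or still open, it means among the compounds named here.

Measured compounds:
compound 1 `N#Cc1cc(NCc2ccccc2[N+](=O)[O-])c2cn[nH]c2c1` — > 100000 nM
compound 2 `COC(=O)c1cc(NCc2ccccc2[N+](=O)[O-])c2cn[nH]c2c1` — > 100000 nM
compound 3 `OC1CCCC(Nc2cccc(CNc3cc(C(F)(F)F)cc4[nH]ncc34)c2)C1` — > 100000 nM

In an assay for inhibition of Indoleamine 2,3-dioxygenase 1 (Homo sapiens), with stated times of 10 min and 60 min (a higher number here means a weaker inhibitor, a lower number a stronger inhibitor), compound 1 gives only a limit of the assay, not a number. Compound 2 likewise gives only a limit in this assay. Compound 3 also gives only a limit. Every value shown sits at that limit (the limit of > 100000 nM in this assay, at which 3 of the 3 values shown sit). The step that the two limits leave unreadable from compound 1 to compound 2 lies between two limits and its size cannot be read. Compound 2 thus stands at the limit, with no readable step around it.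

Compound 4 `O=[N+]([O-])c1ccccc1CNc1cc(C(F)(F)F)cc2[nH]ncc12` differs from compound 2 by trifluoromethyl in place of methoxycarbonyl on an aromatic carbon. Within the data shown here, no measured step covers this change. Compound 3 also carries a trifluoromethyl group on the shared core and sits at the limit. The step that the limit leaves unreadable from compound 2 to compound 4 is therefore expected to be unreadable or small. Compound 4 is estimated at 150000 nM, between 50000 nM and 500000 nM.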

Compound 4, half-maximal inhibitory concentration: 14000 nM
For compound 4 the middle estimate is 11-fold (1.03 log units) above the measured one, and the stated range ends above it.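

In this assay, this aromatic carbon of the shared core proves sensitive to its substituent: trifluoromethyl in place of methoxycarbonyl gives an at least 7.1-fold lower number from compound 2 to compound 4 (0.85 log units; beyond the scatter), and trifluoromethyl in place of cyano gives an at least 7.1-fold lower number from compound 1 to compound 4 (0.85 log units; beyond the scatter). Both steps are minimum sizes, as compound 1 and compound 2 give only limits. Compound 4 alone has a value off the limit: the limit of > 100000 nM in this assay, at which 3 of the 4 values shown sit.

From the compounds shown here alone, whether a chlorine atom, a methyl group or a hydrogen at this carbon would match trifluoromethyl stays open. So does the effect of an amine or a carboxylic acid in place of the nitro group of compound 4.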